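Dichlorophenyl in place of phenyl on the anilino nitrogen

The source may report more compounds than this note shows. Statements on the series, on what has been measured and on what is new or still open speak of the compounds shown alone.

Measured so far:
compound 1 `CCc1ccc(NCC(=O)Nn2c(-c3ccccc3)nc3ccccc3c2=O)cc1` gives 2420 nM
compound 2 `O=C(CNc1ccccc1)Nn1c(-c2ccccc2)nc2ccccc2c1=O` gives 15300 nM

Of the compounds shown here, two sharing one core have been tested in a functional assay on MCF7 cells (Homo sapiens) for cytotoxicity, read by MTT assay, with a stated time of 4 h; a higher number here means a weaker inhibitor, a lower number a stronger inhibitor. Compound 2 has the highest of the two numbers; its nearest neighbour is compound 1, and the step of a 6.3-fold higher number from compound 1 to compound 2 (0.80 log units; beyond the scatter) shows that replacing the ethyl group on the aromatic carbon with hydrogen raised the number, so the unsubstituted phenyl ring gives the weaker compound of the pair.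

Compound 3 `O=C(CNc1ccc(Cl)cc1Cl)Nn1c(-c2ccccc2)nc2ccccc2c1=O` is not yet measured. It differs from compound 2 by 2,4-dichlorophenyl in place of phenyl on an amine nitrogen. Within the data shown here, the only step known bears on substitution of the same ring: the step of a 6.3-fold higher number from compound 1 to compound 2 (0.80 log units; beyond the scatter) was modest and moved the number upward when a substituent was removed. Putting two chlorines onto the ring is a different change, but on that single step a drop in this assay below compound 2 is expected, of roughly a 3.8-fold lower number from compound 2 to compound 3 (0.58 log units; beyond the scatter). Compound 3 is therefore estimated at 4000 nM, within the range 1000 nM to 16000 nM.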

Compound 3, half-maximal inhibitory concentration: 4410 nM
The estimate for compound 3 lay 1.1-fold (0.04 log units) below the measured number; measured number inside the range.
By their numbers in this assay, from the lowest: compounds 1 and 3 (each within the scatter of the next); then compound 2.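

In this assay, among these compounds, the ring on the amine nitrogen now shows a second substitution that lowers the number: 2,4-dichlorophenyl in place of phenyl gives a 3.5-fold lower number from compound 2 to compound 3 (0.54 log units; beyond the scatter) and so ethyl is no longer the only group seen to do this. The two substituted rings cannot be told apart, since 2,4-dichlorophenyl in place of 4-ethylphenyl gives a 1.8-fold higher number from compound 1 to compound 3 (0.26 log units; within the scatter) and that step stays within the scatter. No measurement here explains why either substituted ring differs from plain phenyl.

Going by these compounds, whether a single chlorine on this ring would do as much as two remains open, as does the outcome with a methoxy group or a carboxylic acid there. The phenyl on the shared core is the same in all three compounds, so these results say nothing about changes at that place.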